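This account rests on a few compounds, and the source may have more. Where it says the series, first, only, none or still open, it means among the compounds named here.

Series notes. Compound 2 `Cc1nc2cc(C(=O)NCC3CCCCC3)nn2c(-c2cc(F)c3c(c2C)CCCO3)c1[C@H](OC(C)(C)C)C(=O)O` in an ADME assay on MT2 cells (Homo sapiens) for cytotoxicity (a lower number here means that less compound is tolerated, a higher number that more compound is tolerated), gives > 40000 nM, which is a limit of the assay and not a number. Compound 1 `CCc1cc(CNC(=O)c2cc3nc(C)c([C@H](OC(C)(C)C)C(=O)O)c(-c4cc(F)c5c(c4C)CCCO5)n3n2)ccc1F` in this assay gives > 40000 nM, likewise a limit. The step that the two limits leave unreadable from compound 1 to compound 2 cannot be sized; the evidence rests only on (the limit of > 40000 nM in this assay, at which 2 of the 2 values shown sit). Compound 3 `Cc1nc2cc(C(=O)NCCC3CCCCC3)nn2c(-c2cc(F)c3c(c2C)CCCO3)c1[C@H](OC(C)(C)C)C(=O)O` differs from compound 2 by cyclohexylmethyl in place of cyclohexyl on a saturated chain carbon bound to an amide-type nitrogen. Going by the values given here, no measured step bears readably on this change, so no movement beyond the scatter is expected, and compound 3 is expected to sit at the limit again, a step that the limit leaves unreadable from compound 2 to compound 3. The estimate for compound 3 is 50000 nM, with a range of 25000 nM to 100000 nM.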

Compound 3, half-maximal cytotoxic concentration: > 40000 nM
Compound 3 ended at the assay's limit; the forecaster's own chance of this, stated with the estimate: 85%; the middle value does not contradict the limit.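

In this assay compound 3 gives > 40000 nM as a limit and not a number, so its steps from compound 1 and compound 2 cannot be read. Open remains whether any group on the saturated chain carbon bound to the amide-type nitrogen moves this read-out at all.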